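Naphthyl substituent swap in a sulfonamide series: cytotoxicity notes

This account rests on a few compounds, and the source may have more. Where it says the series, first, only, none or still open, it means among the compounds named here.

Measured in an ADME assay on C8166 cells (Homo sapiens) for cytotoxicity, read by MTT assay (a lower number here means that less compound is tolerated, a higher number that more compound is tolerated), so far:
compound 1 `Cc1cc(S(N)(=O)=O)ccc1NC(=O)COc1ccc(Cl)cc1Oc1ccc2ccccc2c1`: 119000 nM
compound 2 `Cc1cc(S(N)(=O)=O)ccc1NC(=O)COc1ccc(Cl)cc1Oc1ccc2ccccc2c1Br`: 48100 nM
compound 3 `Cc1cc(S(N)(=O)=O)ccc1NC(=O)COc1ccc(F)cc1Oc1cc2ccccc2cc1C`: 66900 nM

Compound 3 stands second highest of the three numbers in this assay; its gaps to compound 2 and to compound 1 both lie within the scatter, so the three are not separated in any reliable way. Compound 4 `Cc1cc(S(N)(=O)=O)ccc1NC(=O)COc1ccc(F)cc1Oc1ccc2ccccc2c1Cl` differs from compound 3 by 1-chloronaphthalen-2-yl in place of 3-methylnaphthalen-2-yl on an oxygen on an aromatic ring. Going by the values given here, the only measured step that bears on this is a 2.5-fold lower number from compound 1 to compound 2 (0.39 log units; beyond the scatter), a modest step. That step adds a halogen in place of hydrogen, whereas here a chlorine enters while a methyl leaves, so the parallel is loose. A small step down, or none beyond the scatter, is expected: a 1.5-fold lower number from compound 3 to compound 4 (0.17 log units; within the scatter). Compound 4 is therefore estimated at 45000 nM, with a range from 20000 nM to 100000 nM.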

Compound 4, half-maximal cytotoxic concentration: 47100 nM
The estimate for compound 4 lay 1.0-fold (0.02 log units) below the measured number; the measured number falls inside the stated range.
By their numbers in this assay, from the lowest: compounds 4, 2, 3 and 1 (each within the scatter of the next, the first and the last beyond it).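

In this assay, 1-chloronaphthalen-2-yl in place of 3-methylnaphthalen-2-yl on an oxygen on an aromatic ring gives a 1.4-fold lower number from compound 3 to compound 4 (0.15 log units; within the scatter), so this exchange does not separate the two compounds. This is the first step shown in which one substituted naphthyl group replaces another, and the series tolerates it here without a reliable shift. No measurement is available that accounts for this result. On these data alone, it remains open whether an amine, a carboxylic acid or a longer chain on the naphthyl group would leave the number similarly unmoved.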